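Removing a Nitro Group on a Sigma Receptor Ligand

The source may report more compounds than this note shows. Statements on the series, on what has been measured and on what is new or still open speak of the compounds shown alone.

Compound 1 `COC(=O)C1(c2ccc(C)cc2)CC1CN1CCC(Cc2ccccc2)CC1`: 0.97 nM
Compound 2 `COC(=O)C1(c2ccc([N+](=O)[O-])cc2)CC1CN1CCN(c2ccccn2)CC1`: 769 nM

In an assay for displacement of a labelled ligand from Sigma non-opioid intracellular receptor 1 (Cavia porcellus) (a lower number here means a stronger inhibitor, a higher number a weaker inhibitor), compound 1 gives 0.97 nM. Compound 2 stands at the top of the two numbers, with 769 nM, and its gap from compound 1 lies well beyond the usual scatter. Compound 3 `COC(=O)C1(c2ccccc2)CC1CN1CCN(c2ccccn2)CC1` has not yet been measured. It differs from compound 2 in one place: hydrogen in place of nitro on an aromatic carbon. For the measured compounds named here, no measured pair shares this single change, so there is no measured step to lean on; the expected step is a 2.2-fold lower number from compound 2 to compound 3 (0.34 log units; beyond the scatter), a modest move toward a stronger inhibitor. Compound 3 is estimated at 350 nM, with a range from 80 nM to 1500 nM.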

Compound 3, inhibition constant: 1330 nM
For compound 3 the middle estimate is 3.8-fold (0.58 log units) below the measured one; low and high end bracket the measured number.
By their numbers in this assay, from the lowest: compound 1; then compounds 2 and 3 (each within the scatter of the next).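

In this assay, going from 4-nitrophenyl to phenyl gives a 1.7-fold higher number from compound 2 to compound 3 (0.24 log units; within the scatter). On this aromatic carbon, then, nitro and hydrogen cannot be told apart, even though three heavy atoms leave with the nitro group. No measurement shown here explains this result. Still open, on these data alone, is whether an amine or a carboxylic acid at this same place would also leave the number within the scatter. Also open, as far as these compounds go, is whether the change from 4-nitrophenyl to phenyl would read the same on the core of compound 1.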